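Meta-halogen swap in the cyclohexyl urea series

The source may report more compounds than this note shows. Statements on the series, on what has been measured and on what is new or still open speak of the compounds shown alone.

Within the data shown here, compound 3 `O=C(Nc1cccc(Br)c1)N[C@H]1CC[C@H](Oc2ccc(F)cc2)CC1` holds the only numerical value in a functional assay on CRL2813 cells (Homo sapiens) for cytotoxicity, read by sulforhodamine B assay, with a stated time of 5 days; a lower number here means a stronger inhibitor, a higher number a weaker inhibitor: compound 3 gives 6200 nM. Compound 1 `O=C(Nc1ccc(Br)cc1)N[C@H]1CC[C@H](Oc2ccc(F)cc2)CC1` reaches only a limit, > 20000 nM. Compound 2 `CSc1ccccc1NC(=O)N[C@H]1CC[C@H](Oc2ccc(F)cc2)CC1` likewise sits at a limit, > 20000 nM. Both limits are the limit of > 20000 nM in this assay, at which 2 of the 3 values shown sit. The steps of an at least 3.2-fold lower number from compound 1 to compound 3 (0.50 log units; beyond the scatter) and an at least 3.2-fold lower number from compound 2 to compound 3 (0.50 log units; beyond the scatter) each arrive at 3-bromophenyl and show that it alone gives a readable number; the step that the two limits leave unreadable from compound 1 to compound 2 cannot be sized. Compound 4 `O=C(Nc1cccc(Cl)c1)N[C@H]1CC[C@H](Oc2ccc(F)cc2)CC1` differs from compound 3 by chloro in place of bromo on an aromatic carbon. Among the measured compounds shown here, no measured step exchanges one halogen for another, so none bears on this change directly; the 3-bromophenyl result is the only anchor. Compound 4 is expected near compound 3, with the step of a 1.1-fold higher number from compound 3 to compound 4 (0.05 log units; within the scatter) estimated to stay within the scatter. The estimate for compound 4 in this assay is 7000 nM, with a range from 2500 nM to 20000 nM.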

Compound 4, half-maximal inhibitory concentration: 5900 nM
The estimate for compound 4 lay 1.2-fold (0.07 log units) above the measured number; measured number inside the range.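

In this assay, the direct halogen exchange gives a 1.1-fold lower number from compound 3 to compound 4 (0.02 log units; within the scatter), so chloro and bromo read alike on this aromatic carbon, meta to a large group. A readable number therefore no longer belongs to 3-bromophenyl alone: an at least 3.3-fold lower number from compound 2 to compound 4 (0.53 log units; beyond the scatter) and an at least 3.3-fold lower number from compound 1 to compound 4 (0.53 log units; beyond the scatter) extend the same contrast to 3-chlorophenyl. Both of these steps are bounds only, because one end of each sits at a limit: the limit of > 20000 nM in this assay, at which 2 of the 4 values shown sit.

Still open, on these data alone, is whether fluoro, methyl or a nitrile on the same carbon stays within the scatter of compound 3 and compound 4. Also open, as far as these compounds go, is whether an amine or a carboxylic acid there keeps a readable number.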